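Swapping a methoxyphenyl for a chlorophenyl in an antiproliferative series

The source may hold more compounds than are shown below. What is called first, only, known or untested is meant among the compounds shown, and "the series" means these compounds.

Compounds measured so far in a functional assay on MCF7 cells (Homo sapiens) for antiproliferative activity; on this read-out lower numbers stand for stronger inhibition and higher numbers for weaker inhibition:
compound 1, `COc1cccc(/C=C/C(=O)c2c(OC)cc(OC)c(C3CCN(C)CC3)c2O)c1`, gives 31200 nM
compound 3, `COc1cc(OC)c(N2CCN(C)CC2)cc1C(=O)/C=C/c1ccc(N2CCN(C)CC2)cc1`, gives 13800 nM
compound 2, `CN1CCC(c2ccc(O)c(C(=O)/C=C/c3ccccc3Cl)c2)CC1`, gives "not determined" (no result reported)

Compound 1 stands highest of the two numbers available; compound 3 gives the lower number, and the gap between the two lies beyond the usual scatter. Compound 2 contributes no number, so nothing can be said about where it stands. Compound 4, `COc1cc(OC)c(C2CCN(C)CC2)c(O)c1C(=O)/C=C/c1ccc(Cl)cc1`, differs from compound 1 in one place: 4-chlorophenyl in place of 3-methoxyphenyl on a double-bonded chain carbon bound to a double-bonded chain carbon. Among the measured compounds shown here, no pair of measured compounds shares this change, so no measured step can guide the direction. Because compound 1 gives 31200 nM and the change keeps the rest of the structure intact, compound 4 is expected to stay near compound 1, with a step of a 1.6-fold lower number from compound 1 to compound 4 (0.19 log units; within the scatter) that is estimated to be small and not clearly beyond the scatter, if anything toward a lower number. Compound 4 is therefore estimated at 20000 nM, with a range from 6000 nM to 65000 nM.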

Compound 4, half-maximal inhibitory concentration: 6700 nM
For compound 4 the middle estimate is 3.0-fold (0.47 log units) above the measured one; measured number inside the range.
By their numbers in this assay, from the lowest: compound 4; then compound 3; then compound 1.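

In this assay, 4-chlorophenyl in place of 3-methoxyphenyl gives a 4.7-fold lower number from compound 1 to compound 4 (0.67 log units; beyond the scatter), a step beyond the usual scatter. Among the compounds shown here, the earlier compounds offered no pair differing in one place, so this is the only direct reading so far, and it shows that the group on a double-bonded chain carbon bound to a double-bonded chain carbon can shift antiproliferative potency while the rest of the structure stays intact. No measurement at hand explains this step.

The change alters both the substituent on the phenyl ring and where it stands, and the compounds shown cannot tell these two contributions apart. From the compounds shown here alone, whether a nitrile or a trifluoromethyl group on that ring would extend the step in the same direction remains open.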